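A few compounds are considered here, and "the series" means these few. Any claim that something is new, unique, unknown or untested is made for them only; others in the source may bear on it.

For the measured compounds named here, compound 3 `CN1CCN(C(=O)c2cnc(C(=O)CCCCCCc3ccccc3)o2)CC1` gives 80 nM in an assay (Rattus norvegicus) for inhibition of Fatty-acid amide hydrolase 1 (Homo sapiens) (on this read-out higher numbers stand for weaker inhibition and lower numbers for stronger inhibition), the highest of the three numbers so far, although its gap to compound 2 `O=C(CCCCCCc1ccccc1)c1ncc(-c2ccc(F)cc2)o1`, which gives 62 nM, and to compound 1 `O=C(O)c1ccc(-c2cnc(C(=O)CCCCCCc3ccccc3)o2)cc1`, which gives 60 nM, lies within the scatter. Compound 4 `CSc1cnc(C(=O)CCCCCCc2ccccc2)o1` differs from compound 3 by methylsulfanyl in place of (4-methylpiperazin-1-yl)carbonyl on an aromatic carbon. Going by the values given here, the steps that bear on this spot are a 1.3-fold higher number from compound 1 to compound 3 (0.12 log units; within the scatter) and a 1.3-fold higher number from compound 2 to compound 3 (0.11 log units; within the scatter), with a 1.0-fold higher number from compound 1 to compound 2 (0.01 log units; within the scatter) alongside; none of them left the scatter even though the groups at that position were very different. A similarly small step is therefore expected, leaning toward a higher number, estimated at a 1.4-fold higher number from compound 3 to compound 4 (0.14 log units; within the scatter). Compound 4 is expected to give 110 nM, within a range from 35 nM to 350 nM.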

Compound 4, inhibition constant: 25 nM
Beside the measured number, compound 4's estimate is 4.4-fold (0.64 log units) above it; the measured number lies below the stated range.
By their numbers in this assay, from the lowest: compound 4; then compounds 1, 2 and 3 (each within the scatter of the next).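

For the compounds shown here, this position is less indifferent than the earlier compounds suggested: methylsulfanyl, the group with the fewest heavy atoms here, gives a 3.2-fold lower number from compound 3 to compound 4 (0.51 log units; beyond the scatter) and a 2.5-fold lower number from compound 2 to compound 4 (0.39 log units; beyond the scatter) and a 2.4-fold lower number from compound 1 to compound 4 (0.38 log units; beyond the scatter). All three steps are modest but beyond the scatter, so compound 4 gives the lowest number of the four. No measurement here explains this gain. Going by these compounds, whether the sulfur atom or the small group matters stays open, and a methoxy group, a plain methyl or a bare hydrogen on the same aromatic carbon would help separate the two.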